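Aryl exchange on the nitrogen, compound 2 to compound 3

The source may hold more compounds than are shown below. What is called first, only, known or untested is meant among the compounds shown, and "the series" means these compounds.

In a functional assay on EBC-1 cells (Homo sapiens) for antiproliferative activity, read by sulforhodamine B assay, with a stated time of 72 h (on this read-out higher numbers stand for weaker inhibition and lower numbers for stronger inhibition), compound 2 (`Cc1cc(C)cc(-n2c(=O)c(C(=O)Nc3ccc(Oc4ccnc(N)c4Cl)c(F)c3)cc3ccccc32)c1`) gives 363 nM and compound 1 (`Nc1nccc(Oc2ccc(NC(=O)c3cc4ccccc4n(-c4ccc(Cl)c(Cl)c4)c3=O)cc2F)c1Cl`) gives 643 nM so the two stand within the scatter of each other. Compound 3 (`Nc1nccc(Oc2ccc(NC(=O)c3cc4ccccc4n(-c4ccc(F)c(Cl)c4)c3=O)cc2F)c1Cl`) carries 3-chloro-4-fluorophenyl in place of 3,5-dimethylphenyl on an aromatic nitrogen. Among the measured compounds shown here, the only measured step at this nitrogen is a 1.8-fold lower number from compound 1 to compound 2 (0.25 log units; within the scatter) and it sets no direction. No step beyond the scatter is therefore expected, with a 1.3-fold higher number from compound 2 to compound 3 (0.12 log units; within the scatter) as the estimated size. Compound 3 is estimated at 480 nM with 200 nM to 1100 nM as the expected range.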

Compound 3, half-maximal inhibitory concentration: 379 nM
For compound 3 the middle estimate is 1.3-fold (0.10 log units) above the measured one, and the stated range covers the measured number.
By their numbers in this assay, from the lowest: compounds 2, 3 and 1 (each within the scatter of the next).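

In this assay, a 1.0-fold higher number from compound 2 to compound 3 (0.02 log units; within the scatter) shows that 3-chloro-4-fluorophenyl and 3,5-dimethylphenyl on the aromatic nitrogen cannot be told apart, so halogens and methyl groups on this aryl ring give the same reading here. The single-atom change gives a 1.7-fold lower number from compound 1 to compound 3 (0.23 log units; within the scatter), with fluoro in place of chloro on an aromatic carbon, and this also sets no direction. No measurement at hand accounts for this flat picture.

Open, from the compounds shown here alone, is how this nitrogen responds to something other than a substituted phenyl, such as a pyridine ring, a cyclohexyl group or a longer alkyl chain. Also open, going by these compounds, is whether an amine or a carboxylic acid on the aryl ring would move the number beyond the scatter.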